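The compounds below may be only part of what the source reports. "The series", "measured", "known", "first", "only" and "open" are said of these compounds alone.

Measured so far in an assay on Sf9 cells for inhibition of histone deacetylase 11 (Homo sapiens), read by fluorescence, tested at 0.5 uM; on this read-out lower numbers stand for less inhibition and higher numbers for more inhibition at the one concentration tested (going by the name of the read-out):
Compound 1 `O=C(NO)c1ccc(-c2cn([C@@H]3C[C@H](C(=O)O)N(CCCc4ccccc4)C3)nn2)cc1` gives < 10%, a limit of the assay rather than a number.
Compound 2 `O=C(NO)c1ccc(-c2cn([C@@H]3C[C@H](C(=O)O)N(Cc4ccccc4)C3)nn2)cc1` gives < 10%, again a limit of the assay.
Compound 3 `O=C(NO)c1ccc(-c2cn([C@@H]3C[C@@H](C(=O)O)N(Cc4ccccc4)C3)nn2)cc1` gives < 10%, also a limit of the assay.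

Compound 2 therefore stands at the limit, and no number places it against its neighbours. The unmeasured compound 4 `O=C(NO)c1cccc(-c2cn([C@@H]3C[C@H](C(=O)O)N(Cc4ccccc4)C3)nn2)c1` has the same atoms as compound 2, joined differently: 3-(hydroxycarbamoyl)phenyl in place of 4-(hydroxycarbamoyl)phenyl on an aromatic carbon. The measured steps that could guide this change are a step that the two limits leave unreadable from compound 1 to compound 2 and a step that the two limits leave unreadable from compound 2 to compound 3; their sizes cannot be read because of the limit of < 10% in this assay, at which 3 of the 3 values shown sit. Nothing in these data shows that changing the substituent on the amine nitrogen or the configuration at a ring carbon lifts the read-out out of the limit, and the present change is expected to behave alike. The step that the limit leaves unreadable from compound 2 to compound 4 is expected to stay within the scatter. Compound 4 is estimated to give 5%, with a range from 0% to 15%.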

Compound 4, a percentage reported as inhibition, at one concentration (the size of the read-out at that concentration, not a potency): < 10%
Compound 4: only a limit was reported; the forecaster's own chance of this, stated with the estimate: 85%; the middle value lies beyond the limit too.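

No size can be read for the step between compound 2 and compound 4, as both sit at a limit of this assay and give no number: the limit of < 10% in this assay, at which 4 of the 4 values shown sit.

The compounds shown leave open whether any change to the shared core can lift the read-out clear of that limit.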